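Trading hydroxy for hexyl on a shared core

The source may report more compounds than this note shows. Statements on the series, on what has been measured and on what is new or still open speak of the compounds shown alone.

Compound 2 `O=c1cc(Cn2cc(CCO)nn2)c2ccc(O)cc2o1` stands only at a limit of a functional assay on SW-620 cells (Homo sapiens) for inhibition, read by MTT assay, with a stated time of 72 h; on this read-out higher numbers stand for weaker inhibition and lower numbers for stronger inhibition: in this assay compound 2 gives > 100000 nM, which is a limit and not a number. Compound 3 `O=c1cc(Cn2cc(CCCCO)nn2)c2ccc(O)cc2o1` likewise returns only a limit, > 100000 nM. Within the data shown here, compound 1 `O=c1cc(Cn2cc(CCCCl)nn2)c2ccc(O)cc2o1` is the one compound with a measured number, giving 59800 nM in this assay. The change to compound 4 `CCCCCCCCc1cn(Cc2cc(=O)oc3cc(O)ccc23)nn1` is hexyl in place of hydroxy on a saturated chain carbon, two bonds along the chain from an aromatic carbon. The measured steps that bear on it run into the limit: an at least 1.6-fold higher number from compound 1 to compound 2 (0.22 log units; that floor lies within the scatter) and an at least 1.6-fold higher number from compound 1 to compound 3 (0.22 log units; that floor lies within the scatter), while a step that the two limits leave unreadable from compound 2 to compound 3 cannot be read because two of the three results rest on (the limit of > 100000 nM in this assay, at which 2 of the 3 values shown sit). The move from hydroxy to hexyl runs opposite to the step from chloromethyl to hydroxy, so compound 4 is expected to come back to a measurable number near compound 1 rather than clearly beyond it, an expected step of an at least 2.0-fold lower number from compound 2 to compound 4 (0.30 log units; that floor lies within the scatter). Compound 4 is therefore estimated at 50000 nM, within 15000 nM to 150000 nM, with a real chance that this assay again reports only a limit.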

Compound 4, half-maximal inhibitory concentration: 50900 nM
The estimate for compound 4 lay 1.0-fold (0.01 log units) below the measured number, within the range that was stated.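

The hexyl group in place of hydroxy, on a saturated chain carbon, two bonds along the chain from an aromatic carbon, turns a limit into a measured number in this assay, with an at least 1.9-fold lower number from compound 2 to compound 4 (0.29 log units; that floor lies within the scatter). Butyl in place of hydroxy, four bonds along the chain from an aromatic carbon, reads the same way, with an at least 1.9-fold lower number from compound 3 to compound 4 (0.29 log units; that floor lies within the scatter), and both steps are only floors: the limit of > 100000 nM in this assay, at which 2 of the 4 values shown sit. Pentyl in place of chloro gives a 1.2-fold lower number from compound 1 to compound 4 (0.07 log units; within the scatter), so the two chains that return a measured number cannot be told apart here.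

Going by these compounds, what an amine or a carboxylic acid in place of the hydroxy would give on this chain stays open. So does whether a chain longer than octyl would carry the number beyond the scatter.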